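Triazole nucleosides: a pyridyl in place of hydroxyethyl

A few compounds are considered here, and "the series" means these few. Any claim that something is new, unique, unknown or untested is made for them only; others in the source may bear on it.

Compound 1 `CCCCCCc1cn([C@@H]2O[C@H](CO)[C@@H](O)[C@H]2O)nn1`: > 200000 nM
Compound 2 `CC(O)c1cn([C@@H]2O[C@H](CO)[C@@H](O)[C@H]2O)nn1`: > 200000 nM

In a functional assay on L1210 cells (Mus musculus) (a lower number here means a stronger inhibitor, a higher number a weaker inhibitor), compound 1 gives > 200000 nM, which is a limit of the assay rather than a number. In this assay compound 2 likewise gives > 200000 nM, again a limit and not a number. The step that the two limits leave unreadable from compound 1 to compound 2 therefore cannot be sized. Where compound 2 stands is thus known only as a limit; the one other value shown is a limit too, as the limit of > 200000 nM in this assay, at which 2 of the 2 values shown sit, records.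

Compound 3 `OC[C@H]1O[C@@H](n2cc(-c3ccccn3)nn2)[C@H](O)[C@@H]1O` is built on the same core as compound 2 and differs from it in one place: pyridin-2-yl in place of 1-hydroxyethyl on an aromatic carbon. No measured step bears on this change, since the only step shown, from hexyl to 1-hydroxyethyl, is unreadable between two limits. What is known is that both shown compounds sit at the limit of this assay, and the change to a pyridin-2-yl group gives no measured ground to expect anything else. Compound 3 is therefore expected to give about 200000 nM in this assay, with a range from 30000 nM to 400000 nM, most likely again reported only as a limit. The expected step is a number no higher from compound 2 to compound 3 (the limit leaves the size open).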

Compound 3, half-maximal inhibitory concentration: 236000 nM
The estimate for compound 3 lay 1.2-fold (0.07 log units) below the measured number; low and high end bracket the measured number.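

The steps linking compound 3 to compound 1 and to compound 2 cannot be read, because compound 1 and compound 2 stand only as limits in this assay: the limit of > 200000 nM in this assay, at which 2 of the 3 values shown sit.

The compounds shown leave open how far compound 1 and compound 2 lie from compound 3, and whether any group at this place on the shared core gives a stronger inhibitor.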